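Swapping the amine-bearing ring for a hydroxyl-bearing one

This account rests on a few compounds, and the source may have more. Where it says the series, first, only, none or still open, it means among the compounds named here.

Of the compounds shown here, three share a core and have been tested in an ADME assay on microsomes from liver (Mus musculus) for metabolic stability, read by LC-MS, using NADPH, with a stated time of 10 min, tested at 10 uM; on this read-out lower numbers stand for a shorter-lived compound and higher numbers for a longer-lived compound. Compound 1 `CC(C)(C)n1nc(Oc2cc(O)ccn2)c2c(N)ncnc21` gives 0.617 h, compound 2 `N#Cc1ccnc(Oc2nn(C3CCC3)c3ncnc(N)c23)c1` gives 0.4 h, and compound 3 `Nc1ncnc2c1c(Oc1cc(C(F)(F)F)ccn1)nn2[C@H]1CC[C@@H](N)CC1` gives 0.917 h. Compound 3 sits within the scatter of compound 1 and beyond the scatter above compound 2. Compound 4 `Nc1ncnc2c1c(Oc1cc(C(F)(F)F)ccn1)nn2C1CCC(O)C1` has not yet been measured in this assay; it differs from compound 3 in one place: 3-hydroxycyclopentyl in place of 4-aminocyclohexyl on an aromatic nitrogen. Within the data shown here, with no measured pair showing this change, only a modest shift is expected, the step of a 1.3-fold lower number from compound 3 to compound 4 (0.12 log units; within the scatter) staying within the scatter. Compound 4 is estimated at 0.7 h, with a likely range from 0.35 h to 1.4 h.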

Compound 4, half-life: 0.3 h
Beside the measured number, compound 4's estimate is 2.3-fold (0.37 log units) above it; measured number below the stated range.
By their numbers in this assay, from the lowest: compounds 4, 2, 1 and 3 (each within the scatter of the next, the first and the last beyond it).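

In this assay the group on this aromatic nitrogen proves able to move the half-life: 3-hydroxycyclopentyl in place of 4-aminocyclohexyl gives a 3.1-fold lower number from compound 3 to compound 4 (0.49 log units; beyond the scatter) and so goes beyond the usual scatter. Among these compounds, this is the first comparison here between two compounds that differ in one place. Nothing measured here explains the step.

The change alters the ring size and replaces the amine with a hydroxyl together, and these compounds cannot separate the two. A 4-hydroxycyclohexyl group at this position would keep the six-membered ring and change only the amine.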